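Enaminone series: aryl ketone exchange at the carbonyl

A few compounds are considered here, and "the series" means these few. Any claim that something is new, unique, unknown or untested is made for them only; others in the source may bear on it.

Measured so far:
compound 1, `O=C(C=CNc1cc(-c2ccccc2)nn1-c1ccccc1)c1cccs1` — 15400 nM
compound 2, `COc1ccc(-c2nc3c(c(-c4ccccc4)nn3-c3ccccc3)c(-c3ccc(N4CCN(C)CC4)cc3)c2C#N)cc1` — 2650 nM

Of the compounds shown here, two have been measured in a functional assay on MCF7 cells (Homo sapiens) for inhibition, read by MTT assay, with a stated time of 48 h; a higher number here means a weaker inhibitor, a lower number a stronger inhibitor. Compound 1 gives 15400 nM, the highest of the two numbers; compound 2 gives 2650 nM, a lower number, and the gap between the two lies beyond the scatter. Among the compounds with values here, compound 2 rests on a different, fused core, so the pair does not isolate a single change and no step between them can be drawn; only the two values stand side by side.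

Compound 3, `COc1ccc(C(=O)C=CNc2cc(-c3ccccc3)nn2-c2ccccc2)cc1`, is not yet measured. It differs from compound 1 in one place: 4-methoxyphenyl in place of thiophen-2-yl on a carbonyl carbon. The (thiophen-2-yl)carbonyl becomes a (4-methoxyphenyl)carbonyl; everything else in compound 1 is kept.

Within the data shown here, no measured pair bears on this exchange, so the expectation leans on the value of compound 1 alone. For compound 3 the step of a 1.3-fold lower number from compound 1 to compound 3 (0.11 log units; within the scatter) is expected to be small, in either direction, and probably not beyond the scatter. Compound 3 is therefore estimated at 12000 nM, within a range from 5000 nM to 30000 nM.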

Compound 3, half-maximal inhibitory concentration: 1290 nM
The estimate for compound 3 lay 9.3-fold (0.97 log units) above the measured number; the measured number lies below the stated range.
By their numbers in this assay, from the lowest: compound 3; then compound 2; then compound 1.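

In this assay, within the data shown here, the group on a carbonyl carbon whose other neighbour is a double-bonded chain carbon proves able to move the number strongly: 4-methoxyphenyl in place of thiophen-2-yl gives a 12-fold lower number from compound 1 to compound 3 (1.08 log units; beyond the scatter), the first step that isolates a single place, with compound 3 at 1290 nM. The exchange replaces a five-membered aromatic ring with 1 hetero atom by a six-membered aromatic ring of carbon only and raises the heavy atoms of the group from 5 to 8, while the hydrogen-bond donor and acceptor counts and the net charge of the group stay the same. No measurement at hand explains the size of this step.

From the compounds shown here alone, this single step does not separate the ring exchange from the methoxy group, so its share of each remains open. Phenyl, with no methoxy group, and 4-aminophenyl on the same carbonyl carbon would each test that split, and whether a longer chain or a carboxylic acid on the ring is tolerated also stays unsettled.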